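Swapping Fluoro for Methyl on the Aromatic Ring

This account rests on a few compounds, and the source may have more. Where it says the series, first, only, none or still open, it means among the compounds named here.

Of the compounds shown here, three sharing one core have been measured in an assay on membranes from liver for displacement of a labelled ligand from Sigma non-opioid intracellular receptor 1 (Rattus norvegicus); a lower number here means a stronger inhibitor, a higher number a weaker inhibitor. Compound 1 `O=c1oc2ccccc2n1CC1CCN(Cc2ccccc2)CC1` gives 3.6 nM, compound 2 `O=c1oc2ccccc2n1CC1CCN(Cc2ccc(Cl)cc2Cl)CC1` gives 258 nM, and compound 3 `O=c1oc2ccccc2n1CC1CCN(Cc2ccc(F)cc2)CC1` gives 3.9 nM. Compound 3 stands second of the three numbers, with a 1.1-fold higher number from compound 1 to compound 3 (0.03 log units; within the scatter) lying within the scatter and a 66-fold lower number from compound 2 to compound 3 (1.82 log units; beyond the scatter) lying well beyond it.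

Compound 4 `Cc1ccc(CN2CCC(Cn3c(=O)oc4ccccc43)CC2)cc1` has not yet been measured in this assay. It differs from compound 3 by methyl in place of fluoro on an aromatic carbon. Among the compounds with values here, two measured steps bear on this exchange. The first, a 1.1-fold higher number from compound 1 to compound 3 (0.03 log units; within the scatter), showed that placing fluoro on that aromatic carbon changed nothing beyond the scatter. The second, a 72-fold higher number from compound 1 to compound 2 (1.86 log units; beyond the scatter), showed that 2,4-dichlorophenyl in place of phenyl brought a large loss, but that change involved two chlorines, one of them on a different aromatic carbon, and is not the single-atom exchange considered here. Methyl in place of fluoro on one aromatic carbon is expected to leave the number essentially where it is, so the step of a 1.1-fold lower number from compound 3 to compound 4 (0.05 log units; within the scatter) is expected to stay within the scatter. Compound 4 is therefore estimated at 3.5 nM, with a range from 1.2 nM to 12 nM.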

Compound 4, inhibition constant: 2.9 nM
The estimate for compound 4 lay 1.2-fold (0.08 log units) above the measured number; the measured number falls inside the stated range.
By their numbers in this assay, from the lowest: compounds 4, 1 and 3 (each within the scatter of the next); then compound 2.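

In this assay, the aromatic carbon para to a large group has now carried hydrogen, fluoro and methyl without any difference that can be read: a 1.3-fold lower number from compound 3 to compound 4 (0.13 log units; within the scatter) and a 1.2-fold lower number from compound 1 to compound 4 (0.09 log units; within the scatter) show that a carbon substituent fits the pattern already seen with fluoro. The large gap to the 2,4-dichlorophenyl group remains, at an 89-fold lower number from compound 2 to compound 4 (1.95 log units; beyond the scatter), so a single methyl at this position does not by itself bring a loss of that kind. No measurement available here accounts for this flat response.

On these data alone, it remains open whether a bigger group at this position, such as a tert-butyl or a methoxy group, would leave the number in the same place, since only single-atom groups and hydrogen have been compared there. It is also unclear how the large loss divides between the two chlorines of the 2,4-dichlorophenyl group, and a single chloro at this position would help to separate them.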